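Swapping Methoxymethyl for Cyclopropyl on an Alkene Carbon

The source may hold more compounds than are shown below. What is called first, only, known or untested is meant among the compounds shown, and "the series" means these compounds.

Measured compounds:
Compound 1, `C/C(=C(/c1ccc(/C=C/C(=O)O)cc1)c1ccc2[nH]ncc2c1)c1ccccc1`: 40 nM
Compound 2, `COC/C(=C(/c1ccc(/C=C/C(=O)O)cc1)c1ccc2[nH]ncc2c1)c1ccccc1`: 88 nM
Compound 3, `O=C(O)/C=C/c1ccc(/C(=C(/CCCl)c2ccccc2)c2ccc3[nH]ncc3c2)cc1`: 9 nM

These three compounds share one core and differ only in the group carried on one carbon of a chain double bond. All were tested in a functional assay on MCF7 cells (Homo sapiens) for cytotoxicity, read by CellTiter-Glo, with a stated time of 5 days; on this read-out lower numbers stand for stronger inhibition and higher numbers for weaker inhibition. In this assay compound 2 gives the highest of the three numbers: the step of a 2.2-fold higher number from compound 1 to compound 2 (0.34 log units; beyond the scatter) separates it from compound 1, and the step of a 9.8-fold lower number from compound 2 to compound 3 (0.99 log units; beyond the scatter) separates it from compound 3, so both neighbours lie beyond the scatter on the lower side.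

Compound 4, `O=C(O)/C=C/c1ccc(/C(=C(\c2ccccc2)C2CC2)c2ccc3[nH]ncc3c2)cc1`, has not yet been measured. Its change from compound 2 is cyclopropyl in place of methoxymethyl on a double-bonded chain carbon bound to an aromatic carbon and a double-bonded chain carbon. No measured step involves a cyclopropyl, so the expectation rests on what this position has shown so far. Going by the values given here, every change at it moved the number beyond the scatter, and the only step that leaves methoxymethyl, a 9.8-fold lower number from compound 2 to compound 3 (0.99 log units; beyond the scatter), lowered it, while the step that arrives at methoxymethyl, a 2.2-fold higher number from compound 1 to compound 2 (0.34 log units; beyond the scatter), raised it. Compound 2 therefore stands at the weak end of what this position has given. A modest lowering is expected for compound 4, about a 2.5-fold lower number from compound 2 to compound 4 (0.40 log units; beyond the scatter), though with wide uncertainty. The estimate for compound 4 is 35 nM, with a range from 12 nM to 110 nM.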

Compound 4, half-maximal inhibitory concentration: 13 nM
For compound 4 the middle estimate is 2.7-fold (0.43 log units) above the measured one; measured number inside the range.
By their numbers in this assay, from the lowest: compounds 3 and 4 (each within the scatter of the next); then compound 1; then compound 2.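

In this assay, going by these compounds alone, cyclopropyl is the first ring seen on this double-bonded chain carbon, and it has the same number of heavy atoms as the methoxymethyl it replaces, yet the number falls clearly (a 6.8-fold lower number from compound 2 to compound 4 (0.83 log units; beyond the scatter)), so heavy-atom count alone does not set the result here. Cyclopropyl and the open 2-chloroethyl chain cannot be told apart (a 1.4-fold higher number from compound 3 to compound 4 (0.16 log units; within the scatter)), which shows that a three-membered ring and this chlorine-bearing chain can give similar results at this position. Cyclopropyl also gives a lower number than methyl (a 3.1-fold lower number from compound 1 to compound 4 (0.49 log units; beyond the scatter)), as 2-chloroethyl does, while methoxymethyl in compound 2 goes against this pattern by giving a higher number than methyl.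

Nothing available here explains why these groups differ. A propyl chain would test whether the oxygen of methoxymethyl goes with the higher number, while a cyclobutyl ring or an amine-bearing chain would show how far the lower numbers extend beyond cyclopropyl and 2-chloroethyl.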